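The source may hold more compounds than are shown below. What is called first, only, known or untested is meant among the compounds shown, and "the series" means these compounds.

Compound 1 `C[C@H](NC(=O)[C@@]1(Cc2ccccc2)CCN1C(=O)OCc1ccccc1)C(=O)N(C)C`: in an ADME assay on HELF cells (Homo sapiens) for cytotoxicity, with a stated time of 3 days (on this read-out higher numbers stand for lower toxicity in this test and lower numbers for higher toxicity in this test), compound 1 gives > 100000 nM, which is a limit of the assay.
Compound 2 `C[C@H](NC(=O)[C@@]1(Cc2ccccc2)CCN1C(=O)OCc1ccccc1)C(=O)NC1CCCCC1`: in this assay compound 2 gives 46000 nM.

Compound 2 holds the only measured number shown; the other value is a limit (the limit of > 100000 nM in this assay, at which 1 of the 2 values shown sits). For the measured compounds named here, the single measured step, an at least 2.1-fold lower number from compound 1 to compound 2 (0.33 log units; beyond the scatter), concerns a change on the carbonyl carbon. Compound 3 `CC(C)C[C@H](NC(=O)[C@@]1(Cc2ccccc2)CCN1C(=O)OCc1ccccc1)C(N)=O` differs from compound 2 elsewhere: 1-carbamoyl-3-methylbutyl in place of 1-(cyclohexylcarbamoyl)ethyl on an amide-type nitrogen. Going by the values given here, that step touches a different position, so the one measured step does not directly bear on it. Compound 3 is therefore expected near 65000 nM, within 25000 nM to 150000 nM, implying a 1.4-fold higher number from compound 2 to compound 3 (0.15 log units; within the scatter).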

Compound 3, half-maximal cytotoxic concentration: 66000 nM
The estimate for compound 3 lay 1.0-fold (0.01 log units) below the measured number, within the range that was stated.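

In this assay, 1-carbamoyl-3-methylbutyl in place of 1-(cyclohexylcarbamoyl)ethyl on the amide-type nitrogen gave a 1.4-fold higher number from compound 2 to compound 3 (0.16 log units; within the scatter), so the six-membered ring can go without a change beyond the scatter. Set against the dimethylcarbamoyl side chain, the same group gave an at least 1.5-fold lower number from compound 1 to compound 3 (0.18 log units; that floor lies within the scatter), a floor that, unlike the earlier step, does not clear the scatter. That comparison rests on a limit for compound 1: the limit of > 100000 nM in this assay, at which 1 of the 3 values shown sits.

As far as these compounds go, whether an amine or a carboxylic acid on this side chain would shift the number remains open. So does the separate share of the 3-methylbutyl chain and of the loss of the cyclohexyl group.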